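Hydroxy-methoxyphenyl Hydrazone: Expected Cytotoxicity of Compound 4

This account rests on a few compounds, and the source may have more. Where it says the series, first, only, none or still open, it means among the compounds named here.

Measured compounds:
Compound 1 `O=C(CSc1nnc(-c2ccncc2)o1)N/N=C/c1ccccc1` gives 16700 nM in a functional assay on SW 1116 cells (Homo sapiens) for cytotoxicity, read by MTT assay, with a stated time of 48 h; a lower number here means a stronger inhibitor, a higher number a weaker inhibitor.
Compound 2 `COc1ccc(/C=N/NC(=O)CSc2nnc(-c3ccncc3)o2)cc1` gives 20300 nM in this assay.
Compound 3 `O=C(CSc1nnc(-c2ccncc2)o1)N/N=C/c1cc(Br)cc(Br)c1O` gives 8570 nM in this assay.

All three share one core and differ only in the aromatic group on the carbon that is double-bonded to nitrogen. Compound 1, which carries a plain phenyl there, gives the second highest of the three numbers; its nearest neighbour is compound 2 and its furthest is compound 3, and both of those gaps lie within the scatter.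

Compound 4 `COc1cc(/C=N/NC(=O)CSc2nnc(-c3ccncc3)o2)ccc1O` has not been measured. It differs from compound 1 in one place: 4-hydroxy-3-methoxyphenyl in place of phenyl on a carbon with a double bond to nitrogen

Among the measured compounds shown here, two measured steps bear on this change. Putting a methoxy group on the ring gave a 1.2-fold higher number from compound 1 to compound 2 (0.08 log units; within the scatter), and putting a hydroxyl together with two bromines on the ring gave a 1.9-fold lower number from compound 1 to compound 3 (0.29 log units; within the scatter). Neither step moved the number beyond the scatter, and the change to compound 4 combines a methoxy with a hydroxyl, without bromine. No step beyond the scatter is therefore expected.

Compound 4 is expected to give about 15000 nM in this assay, with a range from 7000 nM to 32000 nM. That estimate means a step of a 1.1-fold lower number from compound 1 to compound 4 (0.05 log units; within the scatter).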

Compound 4, half-maximal inhibitory concentration: 3590 nM
The estimate for compound 4 lay 4.2-fold (0.62 log units) above the measured number, outside the stated range (below it).
By their numbers in this assay, from the lowest: compound 4; then compounds 3, 1 and 2 (each within the scatter of the next, the first and the last beyond it).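

Among the compounds shown here, on the carbon with a double bond to nitrogen, 4-hydroxy-3-methoxyphenyl is the first replacement for phenyl to move the number beyond the scatter in this assay, with a 4.7-fold lower number from compound 1 to compound 4 (0.67 log units; beyond the scatter) after the swap. This group also outperforms both other substituted rings, with a 5.7-fold lower number from compound 2 to compound 4 (0.75 log units; beyond the scatter) when it replaces 4-methoxyphenyl and a 2.4-fold lower number from compound 3 to compound 4 (0.38 log units; beyond the scatter) when it replaces 3,5-dibromo-2-hydroxyphenyl, so compound 4 is the strongest of the four, and this needs no bromine, while a methoxy on its own, as in compound 2, does not give this result. Nothing available here explains why this particular group gives the lowest number.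

From the compounds shown here alone, the four compounds cannot separate the share of the hydroxyl from that of the methoxy, since none has a ring carrying the hydroxyl alone, so it remains unknown whether one group suffices or both are needed. Going by these compounds, it also remains open whether an amine or a carboxylic acid in the hydroxyl's place would keep the lower number, or whether the ethoxy group, a longer chain, could stand in for the methoxy.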